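From Phenyl to 4-Fluorophenyl: What Compound 3 May Show

The compounds below may be only part of what the source reports. "The series", "measured", "known", "first", "only" and "open" are said of these compounds alone.

Measured so far:
compound 1, `CC(=O)c1cc(-c2ccc(F)cc2)cc2cc(-c3ccccc3)[nH]c12`, a limit in this test: > 100000 nM
compound 2, `COc1ccc(-c2cc(C(C)=O)c3[nH]c(-c4ccccc4)cc3c2)cc1`, 47800 nM

Compound 1 `CC(=O)c1cc(-c2ccc(F)cc2)cc2cc(-c3ccccc3)[nH]c12` reaches only a limit in a functional assay on MCF7 cells (Homo sapiens) for cytotoxicity, read by MTT assay, with a stated time of 2 days (on this read-out lower numbers stand for higher toxicity in this test and higher numbers for lower toxicity in this test), namely > 100000 nM. For the measured compounds named here, compound 2 `COc1ccc(-c2cc(C(C)=O)c3[nH]c(-c4ccccc4)cc3c2)cc1` gives 47800 nM in this assay and so holds the only actual number in the set. Going by the values given here, the one measured step, an at least 2.0-fold lower number from compound 1 to compound 2 (0.32 log units; beyond the scatter), starts from the limit of > 100000 nM in this assay, at which 1 of the 2 values shown sits, and is therefore itself only a lower bound on the change.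

Compound 3 `COc1ccc(-c2cc(C(C)=O)c3[nH]c(-c4ccc(F)cc4)cc3c2)cc1` differs from compound 2 by fluoro in place of hydrogen on an aromatic carbon. The measured step concerns a different ring and a different exchange, so nothing measured bears directly on this change. For compound 3 the step is therefore expected to stay within the scatter, a 1.0-fold higher number from compound 2 to compound 3 (0.02 log units; within the scatter). Compound 3 is estimated at 50000 nM, between 15000 nM and 150000 nM.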

Compound 3, concentration lethal to 50% of the cells: 16800 nM
Compound 3: the middle estimate sits 3.0-fold (0.47 log units) above what was measured; low and high end bracket the measured number.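

In this assay, the phenyl group that compound 1 and compound 2 share turns out to be a place where a single exchange matters: 4-fluorophenyl in its stead gives a 2.8-fold lower number from compound 2 to compound 3 (0.45 log units; beyond the scatter). For the compounds shown here, this is the first step in the set with actual numbers at both ends, so its full size can be read, whereas the earlier step starts from a limit: the limit of > 100000 nM in this assay, at which 1 of the 3 values shown sits. Going by these compounds alone, it also shows that the exchange of fluoro for methoxy is not the only change that moves the number beyond the scatter.

The compounds shown carry only hydrogen or fluoro at this place, so it stays open whether a chloro group or an amine there would lower the number further. Also open, from the compounds shown here alone, is whether the same exchange would lower the number on the core of compound 1, which carries fluoro instead of methoxy.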